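The source may report more compounds than this note shows. Statements on the series, on what has been measured and on what is new or still open speak of the compounds shown alone.

Measured so far in a functional assay on BHK cells for positive allosteric modulation of metabotropic glutamate receptor 5 (Homo sapiens), read by FLIPR and calcium flux; on this read-out higher numbers stand for an effect only at larger amounts of compound and lower numbers for an effect already at smaller amounts: compound 1 `O=C(NC1CCCC1)c1ccc(C#Cc2ccccc2)nc1`, 30 nM; compound 2 `CC1CCC(NC(=O)c2ccc(C#Cc3ccccc3)nc2)CC1`, 1200 nM; compound 3 `O=C(NCc1ccco1)c1ccc(C#Cc2ccccc2)nc1`, 180 nM.

Compound 3 stands second highest of the three numbers: a 6.0-fold higher number from compound 1 to compound 3 (0.78 log units; beyond the scatter), and a 6.7-fold lower number from compound 2 to compound 3 (0.82 log units; beyond the scatter). Compound 4 `CC1CCN(C(=O)c2ccc(C#Cc3ccccc3)nc2)CC1` differs from compound 3 by 4-methylpiperidin-1-yl in place of ((furan-2-yl)methyl)amino on a carbonyl carbon. All three measured steps exchange the group on the amide-type nitrogen while keeping the amide hydrogen; a 40-fold higher number from compound 1 to compound 2 (1.60 log units; beyond the scatter), a 6.0-fold higher number from compound 1 to compound 3 (0.78 log units; beyond the scatter) and a 6.7-fold lower number from compound 2 to compound 3 (0.82 log units; beyond the scatter) show that this position moves this assay by modest to large amounts. None of them removes the hydrogen-bond donor counted in the change, so the direction for compound 4 is uncertain, and a modest step towards a higher number is expected, a 3.3-fold higher number from compound 3 to compound 4 (0.52 log units; beyond the scatter). Compound 4 is therefore estimated at 600 nM, within 100 nM to 5000 nM.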

Compound 4, half-maximal effective concentration: 130 nM
Estimate against measurement, compound 4: 4.6-fold (0.66 log units) above; low and high end bracket the measured number.
By their numbers in this assay, from the lowest: compound 1; then compounds 4 and 3 (each within the scatter of the next); then compound 2.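

Among the compounds shown here, compound 4 loses the amide hydrogen, which all the earlier compounds keep, yet in this assay the exchange leaves the number within the scatter (a 1.4-fold lower number from compound 3 to compound 4 (0.14 log units; within the scatter)). The 4-methylpiperidin-1-yl compound falls on either side of the two cycloalkyl amides (a 9.2-fold lower number from compound 2 to compound 4 (0.97 log units; beyond the scatter); a 4.3-fold higher number from compound 1 to compound 4 (0.64 log units; beyond the scatter)), so among these compounds, the presence of the amide hydrogen alone does not set the number. Nothing available explains these differences. Still open, as far as these compounds go, is what a methyl group added on the amide-type nitrogen of compound 1 would do in this assay, and how a morpholine would compare with the 4-methylpiperidin-1-yl group.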